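Swapping an Aromatic Ring for a Long Chain

The compounds below may be only part of what the source reports. "The series", "measured", "known", "first", "only" and "open" are said of these compounds alone.

Compound 3 `CC(C)c1cccc(C(C)C)c1OC(=O)NC(=O)SCc1ccc(Cl)cc1` gives 160 nM in an assay on microsomes from intestine for inhibition of acyl-CoA:cholesterol acyltransferase (Oryctolagus cuniculus) (a lower number here means a stronger inhibitor, a higher number a weaker inhibitor), the highest of the three measured numbers. Compound 1 `CCCCCCOC(=O)NC(=O)Oc1c(C(C)C)cccc1C(C)C` gives 53 nM in this assay, and compound 2 `CCCCCCCCCCCCC(C)(C)OC(=O)NC(=O)Oc1c(C(C)C)cccc1C(C)C` gives 21 nM. For the measured compounds named here, the only measured step that reaches compound 3 is a 3.0-fold higher number from compound 1 to compound 3 (0.48 log units; beyond the scatter). Compound 4 `CCCCCCCCCCCSC(=O)NC(=O)Oc1c(C(C)C)cccc1C(C)C` differs from compound 3 in one place: decyl in place of 4-chlorophenyl on a saturated chain carbon bound to a sulfur. Going by the values given here, no measured step copies this exact change. Still, compound 2 and compound 1 show that the much longer chain goes with the lower of their two numbers, while the 4-chlorophenyl group of compound 3 goes with the highest number of all. The step is therefore expected to be a moderate decrease, estimated as a 3.6-fold lower number from compound 3 to compound 4 (0.55 log units; beyond the scatter). Compound 4 is estimated at 45 nM, within a range from 15 nM to 130 nM.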

Compound 4, half-maximal inhibitory concentration: 210 nM
For compound 4 the middle estimate is 4.7-fold (0.67 log units) below the measured one, outside the stated range (above it).
By their numbers in this assay, from the lowest: compound 2; then compound 1; then compounds 3 and 4 (each within the scatter of the next).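

On the saturated chain carbon bound to a sulfur, decyl and 4-chlorophenyl cannot be told apart in this assay, with a 1.3-fold higher number from compound 3 to compound 4 (0.12 log units; within the scatter). For this pair, then, an aromatic ring at this place is not required, and a chain of carbon alone gives a matching number despite sharing no ring with the group it replaces. No measured evidence here explains why the two groups match. Still open, from the compounds shown here alone, is whether a shorter butyl chain, or a chain ending in an amine or a carboxylic acid, would hold the number at this place. Also open, going by these compounds, is how compound 4 would change with an oxygen in place of the sulfur.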